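Ester Size and Calcium Channel Antagonism in One Series

This account rests on a few compounds, and the source may have more. Where it says the series, first, only, none or still open, it means among the compounds named here.

Measured in an assay on isolated protein for antagonist activity at Voltage-dependent L-type calcium channel subunit alpha-1C (Cavia porcellus), with a stated time of 15 min; a lower number here means a stronger inhibitor, a higher number a weaker inhibitor:
compound 1 `COC(=O)C1=C(C)NC(C)=C(C(=O)OC)C1c1csc(-c2ccc(Cl)cc2)n1` gives 4430 nM;
compound 2 `CC1=C(C(=O)OCC(C)C)C(c2csc(-c3ccc(Cl)cc3)n2)C(C(=O)OCC(C)C)=C(C)N1` gives 24900 nM;
compound 3 `CC1=C(C(=O)OCc2ccccc2)C(c2csc(-c3ccc(Cl)cc3)n2)C(C(=O)OCc2ccccc2)=C(C)N1` gives 11000 nM.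

Compound 1 stands lowest of the three numbers in this assay; compound 3 sits nearest, beyond the scatter, and compound 2 furthest, also beyond it. Both larger diesters thus show higher numbers than compound 1. Compound 4 `COC(=O)C1=C(C)NC(C)=C(C(=O)OC2CCCCC2)C1c1csc(-c2ccc(Cl)cc2)n1` keeps one methyl ester and differs from compound 1 by cyclohexyl in place of methyl on an oxygen next to a carbonyl group. For the measured compounds named here, no directly comparable pair has been measured, so the step is expected to go upward, toward a weaker inhibitor, by a modest amount, since compound 2 at 24900 nM and compound 3 at 11000 nM both lie above compound 1. Compound 4 is therefore estimated at 8000 nM, ranging from 2500 nM to 25000 nM, an expected step of a 1.8-fold higher number from compound 1 to compound 4 (0.26 log units; within the scatter).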

Compound 4, half-maximal inhibitory concentration: 71900 nM
Compound 4: middle estimate off by 9.0-fold (0.95 log units), on the low side; measured number above the stated range.
By their numbers in this assay, from the lowest: compound 1; then compound 3; then compound 2; then compound 4.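

With one methyl ester kept, changing the other ester in this assay gives a 16-fold higher number from compound 1 to compound 4 (1.21 log units; beyond the scatter), with cyclohexyl in place of methyl on an oxygen next to a carbonyl group. For the compounds shown here, this is the first change in a single place, since the earlier diesters differ from compound 1 at both esters. Nothing measured here accounts for the size of this step.

The compounds shown leave open how an ethyl or a longer chain in this place would compare with methyl and cyclohexyl. They also leave open what an amine at the end of that ester chain would do.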